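One Ring Larger: From Cyclopropyl to Cyclobutyl

The compounds below may be only part of what the source reports. "The series", "measured", "known", "first", "only" and "open" are said of these compounds alone.

Of the compounds shown here, three have been measured in a physicochemical assay for lipophilicity (a lower number here means a more polar compound, a higher number a more lipophilic compound), so far. Compound 1 `Cn1ccc(C(=O)N(CC(=O)Nc2cc(F)cc(F)c2)C2CCCCC2)n1` gives 3. Compound 2 `O=C(CN(C(=O)c1ccc(N2CCCC2)cc1)C1CCCCC1)Nc1cc(F)cc(F)c1` gives 4.5. Compound 3 `O=C(CN(CC1CC1)C(=O)c1ccc(-c2ccccn2)cc1)Nc1cc(F)cc(F)c1` gives 3.1, which is within the scatter of compound 1 and lies well short of compound 2, a gap beyond the scatter. For the measured compounds named here, these three differ in more than one place, so they offer no single-change step to serve as a guide.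

Compound 4 `O=C(CN(CC1CCC1)C(=O)c1ccc(-c2ccccn2)cc1)Nc1cc(F)cc(F)c1` has not yet been measured. It departs from compound 3 in one place only: cyclobutyl in place of cyclopropyl on a saturated chain carbon bound to an amide-type nitrogen. In words, cyclobutyl stands in place of cyclopropyl on a saturated chain carbon bound to an amide-type nitrogen, which can also be read as cyclopropylmethyl to cyclobutylmethyl. Both groups are carbon only and carry no net charge.

Going by the values given here, with no measured step to calibrate it, the expectation rests on the structural change alone, and it is for a small move upward in this assay rather than a large one. The estimated change is a number 0.40 log units higher from compound 3 to compound 4 (beyond the scatter), though a result within the scatter of the starting value would not be surprising. For compound 4 the expected value is 3.5, with an estimated range from 3.1 to 3.9.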

Compound 4, distribution coefficient: 3.5
For compound 4 middle estimate and measured number coincide at the digits printed; measured number inside the range.
By their numbers in this assay, from the lowest: compounds 1 and 3 (each within the scatter of the next); then compound 4; then compound 2.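

For the compounds shown here, this is the first change that can be read on its own: in this assay, putting cyclobutyl in place of cyclopropyl on a saturated chain carbon bound to an amide-type nitrogen gives a number 0.40 log units higher from compound 3 to compound 4 (beyond the scatter), a modest step. The two groups are both carbon only, with no hydrogen-bond donors or acceptors and no net charge, so what differs between them is a three-membered against a four-membered ring, and that difference alone is enough to move the number in this assay at this place. No measurement shown here accounts for the size of the step, and it rests on this single pair of compounds.

The compounds shown leave open whether cyclopentyl at the same place would extend the step, or whether an open chain such as isobutyl would match the ring of the same carbon count. They also leave open what happens when a ring carbon gives way to oxygen, as in oxetanyl, or when an amine is placed on the ring.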